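Chloro-to-fluoro swap on a shared anilide series

A few compounds are considered here, and "the series" means these few. Any claim that something is new, unique, unknown or untested is made for them only; others in the source may bear on it.

Measured compounds:
compound 1 `O=C(CSc1nc(Nc2ccccc2)c2ccccc2n1)Nc1ccc(F)cc1` – 9560 nM
compound 2 `O=C(CSc1nc(Nc2ccccc2)c2ccccc2n1)Nc1ccc(Cl)cc1` – 12900 nM
compound 3 `C=CC(=O)Nc1cccc(NC(=O)CSc2nc(Nc3ccc(Cl)c(Cl)c3)c3ccccc3n2)c1` – 27600 nM

In a functional assay on PC-3 cells (Homo sapiens) for inhibition, read by MTT assay, with a stated time of 72 h (a higher number here means a weaker inhibitor, a lower number a stronger inhibitor), compound 1 gives 9560 nM and compound 2 gives 12900 nM. The change between them, (fluoro in place of chloro on an aromatic carbon), gives a 1.3-fold lower number from compound 2 to compound 1 (0.13 log units; within the scatter). Compound 3 gives 27600 nM; the difference between its core and that of compound 2 is not broken down here. Compound 4 `C=CC(=O)Nc1cccc(NC(=O)CSc2nc(Nc3ccc(F)c(Cl)c3)c3ccccc3n2)c1` carries the same kind of change relative to compound 3, (fluoro in place of chloro on an aromatic carbon), but here the place is also ortho to a chloro group (1 heavy atom), which the place in compound 1 is not. Based only on a 1.3-fold lower number from compound 2 to compound 1 (0.13 log units; within the scatter), a step of similar size is expected for compound 4, namely a 1.3-fold lower number from compound 3 to compound 4 (0.12 log units; within the scatter). Compound 4 is therefore estimated at 21000 nM, with a range of 9000 nM to 50000 nM.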

Compound 4, half-maximal inhibitory concentration: > 50000 nM
Compound 4: no number, only a limit; the forecaster's own chance of this, stated with the estimate: 20%; middle value at least 2.3-fold (0.37 log units) from the limit.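

In this assay compound 4 reads > 50000 nM, which is a limit of the assay and not a number. As far as these compounds go, the fluoro-for-chloro change on this core therefore reads as an at least 1.8-fold higher number from compound 3 to compound 4 (0.25 log units; that floor lies within the scatter), a step whose true size stays open. Carrying the change from one core to the other can be neither confirmed nor ruled out: the same change on two cores in this assay, a 1.3-fold lower number (0.13 log units; within the scatter) from compound 2 to compound 1 and an at least 1.8-fold higher number (0.25 log units; that floor lies within the scatter) from compound 3 to compound 4; the limit leaves it open whether they differ

The compounds shown do not separate the place ortho to a chloro group, which only compound 4 carries, from the other differences between the cores. From the compounds shown here alone, how a bromo or a methoxy group in place of the fluoro would read on the core of compound 4 also remains open.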